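Furan in place of pyrrole on an amide-linked aminothiazole

The source may report more compounds than this note shows. Statements on the series, on what has been measured and on what is new or still open speak of the compounds shown alone.

Measured in an assay with sodium channel protein type 4 subunit alpha (Homo sapiens) as the target, read by patch clamp; a higher number here means a weaker inhibitor, a lower number a stronger inhibitor:
Compound 1, `Nc1nc2c(s1)CC(CNC(=O)c1cc(Br)c[nH]1)CC2`, gives > 30000 nM, a limit of the assay.
Compound 2, `Nc1nc2c(s1)C[C@@H](NC(=O)c1ccc[nH]1)CC2`, gives > 30000 nM, also a limit.
Compound 3, `CC(C)(C)OC(=O)N1CCC[C@H]1C(=O)N[C@H]1CCc2nc(N)sc2C1`, gives 8000 nM.

Compound 2 therefore stands at the limit rather than at a number; it shares that limit with compound 1 (the limit of > 30000 nM in this assay, at which 2 of the 3 values shown sit), while compound 3 is the only one of the three with a measured value. Compound 4, `Nc1nc2c(s1)C[C@@H](NC(=O)c1ccco1)CC2`, has not yet been measured. It differs from compound 2 in one place: furan-2-yl in place of 1H-pyrrol-2-yl on a carbonyl carbon. For the measured compounds named here, no step between two measured compounds exists in this set, so there is nothing to calibrate the change against. The expectation is that compound 4 stays at or near the limit, with no step beyond the scatter: the step of a number no higher from compound 2 to compound 4 (the limit leaves the size open) is expected to be flat. For compound 4 the estimated value in this assay is 30000 nM, with a range from 8000 nM to 100000 nM, and most likely the assay again reports only a limit.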

Compound 4, half-maximal inhibitory concentration: > 30000 nM
Compound 4 ended at the assay's limit; the forecaster's own chance of this, stated with the estimate: 70%; the middle value lies on the limit itself.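

The step from compound 2 to compound 4 cannot be read, since both compounds give only a limit in this assay: the limit of > 30000 nM in this assay, at which 3 of the 4 values shown sit.

The compounds shown leave open how far apart compound 2 and compound 4 lie in this assay, and so whether furan-2-yl in place of 1H-pyrrol-2-yl changes anything there.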